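The source may hold more compounds than are shown below. What is called first, only, known or untested is meant among the compounds shown, and "the series" means these compounds.

Measured in an ADME assay on BaF3 cells (Mus musculus) for antiproliferative activity, read by CCK-8 assay, with a stated time of 72 h; a lower number here means a stronger inhibitor of growth, a higher number a weaker inhibitor of growth:
Compound 1 `CNC(=O)CCSc1ccc2c(/C=C/c3ccccn3)n[nH]c2c1`: > 10000 nM
Compound 2 `COc1ccc(NC(=O)CCSc2ccc3c(/C=C/c4ccccn4)n[nH]c3c2)cc1C(F)(F)F`: > 10000 nM

Both results are limits, not numbers. Compound 2 stands at a limit, > 10000 nM, and so sits with compound 1 at the limit of > 10000 nM in this assay, at which 2 of the 2 values shown sit. Compound 3 `O=C(CCSc1ccc2c(/C=C/c3ccccn3)n[nH]c2c1)Nc1ccc(CN2CCCC2)c(C(F)(F)F)c1` has (pyrrolidin-1-yl)methyl in place of methoxy on an aromatic carbon, ortho to a trifluoromethyl group ((pyrrolidin-1-yl)methyl in place of methoxy on an aromatic carbon). For the measured compounds named here, no measured step exists to guide the forecast, so only a modest move toward stronger growth inhibition in this assay is expected, and a result at the limit again remains quite possible. The expected change is an at least 1.6-fold lower number from compound 2 to compound 3 (0.22 log units; that floor lies within the scatter). Compound 3 is estimated at 6000 nM, with an expected range of 1000 nM to 20000 nM.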

Compound 3, concentration for 50% growth inhibition: 4000 nM
Compound 3: the middle estimate sits 1.5-fold (0.18 log units) above what was measured, within the range that was stated.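

Putting (pyrrolidin-1-yl)methyl in place of methoxy, on the aromatic carbon ortho to a trifluoromethyl group, gives an at least 2.5-fold lower number from compound 2 to compound 3 (0.39 log units; beyond the scatter) in this assay, so a change at this position can shift growth inhibition. That step is only a floor, and compound 3 alone gives a number rather than a limit: the limit of > 10000 nM in this assay, at which 2 of the 3 values shown sit.

On these data alone, whether the shift depends on the pyrrolidine ring or on an amine of any kind remains open. A dimethylamino group, a morpholine or a longer chain to the nitrogen would separate these possibilities.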